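Dropping One Chloro From the Amide Aryl Ring

A few compounds are considered here, and "the series" means these few. Any claim that something is new, unique, unknown or untested is made for them only; others in the source may bear on it.

Compound 1 `CCc1cccc(NC(=O)CN2CCC(c3cccc[n+]3[O-])CC2)c1` — 62%
Compound 2 `Cc1cc(NC(=O)CN2CCC(c3cccc[n+]3[O-])CC2)ccc1F` — 75%
Compound 3 `O=C(CN1CCC(c2cccc[n+]2[O-])CC1)Nc1cccc(Cl)c1Cl` — 66%

In a functional assay on HEK293 cells for agonist activity at D(4) dopamine receptor (Homo sapiens), read by FLIPR (on this read-out higher numbers stand for larger maximal responses and lower numbers for smaller maximal responses), compound 3 gives 66%, the second highest of the three numbers; against its neighbours it stands a number 4 percentage points higher from compound 1 to compound 3 (within the scatter) and a number 9 percentage points lower from compound 2 to compound 3 (within the scatter), both within the scatter. Compound 4 `O=C(CN1CCC(c2cccc[n+]2[O-])CC1)Nc1cccc(Cl)c1` differs from compound 3 by hydrogen in place of chloro on an aromatic carbon. Among the compounds with values here, no measured step removes a single chloro; the steps that exchange the whole aryl group on the amide nitrogen, a number 13 percentage points higher from compound 1 to compound 2 (beyond the scatter), a number 4 percentage points higher from compound 1 to compound 3 (within the scatter) and a number 9 percentage points lower from compound 2 to compound 3 (within the scatter), are modest or within the scatter. Compound 4 is therefore expected to show a number 1 percentage points lower from compound 3 to compound 4 (within the scatter), no change beyond the scatter. Compound 4 is estimated at 65%, in a range from 50% to 80%.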

Compound 4, largest response reached (reported as efficacy), in percent of the reference or control that the assay uses: 76%
The estimate for compound 4 lay 11 percentage points below the measured number, and the stated range covers the measured number.
By their numbers in this assay, from the lowest: compounds 1, 3, 2 and 4 (each within the scatter of the next, the first and the last beyond it).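

Within the data shown here, removing this one chloro, which turns 2,3-dichlorophenyl into 3-chlorophenyl, is the first single-atom change read at this place: in this assay it gives a number 10 percentage points higher from compound 3 to compound 4 (within the scatter) and so shows that the response holds without that chloro. Compound 4 also matches the best earlier aryl group, with a number 1 percentage points higher from compound 2 to compound 4 (within the scatter) on exchanging it, while chloro in place of ethyl gives a number 14 percentage points higher from compound 1 to compound 4 (beyond the scatter) as a modest step. Nothing measured here explains these numbers.

Going by these compounds, what a methoxy group or an amine on that same carbon would do remains open.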